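The compounds below may be only part of what the source reports. "The series", "measured", "known", "first", "only" and "open" are said of these compounds alone.

Among the measured compounds shown here, compound 1, `CC(C(=O)N1CCN(c2ccc(C(=O)NCCC3CC3)nn2)CC1)(C(F)(F)F)C(F)(F)F`, is one of two compounds measured so far in an assay on microsomes from liver (strain ICR) for inhibition of acyl-CoA desaturase 1 (Mus musculus), read by scintillation counting, with a stated time of 20 h (a higher number here means a weaker inhibitor, a lower number a stronger inhibitor), where compound 1 gives 113 nM. Compound 2, `O=C(NCCC1CC1)c1ccc(N2CCN(C(=O)C3CC3C(F)(F)F)CC2)nn1`, carries a 2-(trifluoromethyl)cyclopropyl group on the carbonyl carbon in place of the 1,1-bis(trifluoromethyl)ethyl group of compound 1. For compound 2 this assay reports only a limit, > 1000 nM, so its exact value is not known. The change from compound 1 to compound 2 thus gave an at least 8.8-fold higher number from compound 1 to compound 2 (0.94 log units; beyond the scatter), with the limit of > 1000 nM in this assay, at which 1 of the 2 values shown sits, setting the edge of what can be read.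

Compound 3, `CC1CCCCC1C(=O)N1CCN(c2ccc(C(=O)NCCC3CC3)nn2)CC1`, differs from compound 2 by 2-methylcyclohexyl in place of 2-(trifluoromethyl)cyclopropyl on a carbonyl carbon. For the measured compounds named here, only one measured step touches this part of the molecule, and it shows that this position can move the readout a good deal. The change is expected to give an at least 1.6-fold lower number from compound 2 to compound 3 (0.22 log units; that floor lies within the scatter) in this assay. Compound 3 is estimated at 600 nM, in a range from 150 nM to 3000 nM.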

Compound 3, half-maximal inhibitory concentration: 680 nM
Estimate against measurement, compound 3: 1.1-fold (0.05 log units) below; low and high end bracket the measured number.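

Compound 3 shows that this carbonyl carbon can carry a group with no fluorine, 2-methylcyclohexyl, and still give a readable value in this assay. Against compound 2 the change gives an at least 1.4-fold lower number from compound 2 to compound 3 (0.16 log units; that floor lies within the scatter), and this floor cannot show how far apart the two compounds lie, because compound 2 stands at a limit of the assay: the limit of > 1000 nM in this assay, at which 1 of the 3 values shown sits. Against compound 1, the same group gives a 6.0-fold higher number from compound 1 to compound 3 (0.78 log units; beyond the scatter), so the 1,1-bis(trifluoromethyl)ethyl group remains ahead of 2-methylcyclohexyl at this position.

The compounds shown leave open whether a tert-butyl group, which has the branched shape of 1,1-bis(trifluoromethyl)ethyl but only carbon and hydrogen, would read like compound 1. They also leave open how a phenyl ring or an amine-bearing ring would read on this carbonyl carbon.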